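The source may report more compounds than this note shows. Statements on the series, on what has been measured and on what is new or still open speak of the compounds shown alone.

Measured so far in a functional assay on MCF7 cells (Homo sapiens) for antiproliferative activity, read by MTT assay, with a stated time of 24 h; on this read-out higher numbers stand for weaker inhibition and lower numbers for stronger inhibition:
Compound 1 `CCn1c(C(=O)NCCN)ccc1C(CC)(CC)c1ccc(OCS(=O)(=O)c2ccccc2)c(C)c1`: 6470 nM
Compound 2 `CCn1c(C(=O)N[C@H](CO)CCCO)ccc1C(CC)(CC)c1ccc(OCS(=O)(=O)c2ccccc2)c(C)c1`: 31400 nM
Compound 3 `CCn1c(C(=O)N[C@H](C)C(=O)O)ccc1C(CC)(CC)c1ccc(OCS(=O)(=O)c2ccccc2)c(C)c1`: > 50000 nM (a limit, not a number)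

Compound 3 has no exact position on this scale. It gives only the limit of > 50000 nM in this assay.

Compound 4 `CCn1c(C(=O)N[C@@H](CC(=O)O)C(=O)O)ccc1C(CC)(CC)c1ccc(OCS(=O)(=O)c2ccccc2)c(C)c1` differs from it by 1,2-dicarboxyethyl in place of 1-carboxyethyl on an amide-type nitrogen. The closest evidence is an at least 7.7-fold higher number from compound 1 to compound 3 (0.88 log units; beyond the scatter), which placed 1-carboxyethyl on that nitrogen instead of 2-aminoethyl. The step of an at least 1.5-fold higher number from compound 2 to compound 3 (0.20 log units; that floor lies within the scatter) adds little, and a 4.9-fold higher number from compound 1 to compound 2 (0.69 log units; beyond the scatter) also points towards higher numbers. None of these steps tests the new group directly.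

In this assay, a further shift towards higher numbers is therefore expected, or none beyond the scatter. The expected step is a step that the limit leaves unreadable from compound 3 to compound 4. Compound 4 is estimated at 70000 nM, with an expected range of 35000 nM to 200000 nM, and it may well return only a limit.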

Compound 4, half-maximal inhibitory concentration: > 50000 nM
Compound 4: a limit, no number (the forecaster's own chance of this, stated with the estimate: 80%); the middle value does not contradict the limit.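

In this assay, 1,2-dicarboxyethyl in place of 1-carboxyethyl on the amide-type nitrogen brings no exact value back, so the step from compound 3 to compound 4 cannot be read. Set against the other two compounds, the new group gives an at least 7.7-fold higher number from compound 1 to compound 4 (0.88 log units; beyond the scatter), a step from 2-aminoethyl, and an at least 1.5-fold higher number from compound 2 to compound 4 (0.20 log units; that floor lies within the scatter), which fixes no order. Carboxylic acid groups on this nitrogen have so far returned only a ceiling: the limit of > 50000 nM in this assay, at which 2 of the 4 values shown sit.

The compounds shown leave open whether a longer amine chain, such as 3-aminopropyl, would give lower numbers than compound 1. They also leave open whether a methyl ester in place of the carboxylic acid of compound 3 or compound 4 would bring the read-out back to an exact value.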